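Piperazine series: from phenyl to 2-fluorophenyl

The compounds below may be only part of what the source reports. "The series", "measured", "known", "first", "only" and "open" are said of these compounds alone.

Of the compounds shown here, three on a shared core have been read in a functional assay on SK-MEL-28 cells (Homo sapiens) for inhibition, read by MTT assay, with a stated time of 72 h; on this read-out lower numbers stand for stronger inhibition and higher numbers for weaker inhibition. Compound 1 `C/C1=C\CC[C@@]2(C)O[C@@H]2[C@H]2OC(=O)[C@@H](CN3CCCCC3)[C@@H]2C[C@H]1O` gives 16000 nM, compound 2 `C/C1=C\CC[C@@]2(C)O[C@@H]2[C@H]2OC(=O)[C@@H](CN3CCN(C)CC3)[C@@H]2C[C@H]1O` gives 57000 nM, and compound 3 `C/C1=C\CC[C@@]2(C)O[C@@H]2[C@H]2OC(=O)[C@@H](CN3CCN(c4ccccc4)CC3)[C@@H]2C[C@H]1O` gives 19000 nM. Compound 3 thus lies within the usual scatter of compound 1, while compound 2 carries the highest number of the three.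

Compound 4 `C/C1=C\CC[C@@]2(C)O[C@@H]2[C@H]2OC(=O)[C@@H](CN3CCN(c4ccccc4F)CC3)[C@@H]2C[C@H]1O` keeps everything in compound 3 but has fluoro in place of hydrogen on an aromatic carbon, ortho to a large group: fluoro in place of hydrogen on an aromatic carbon. In other words, phenyl becomes 2-fluorophenyl.

Within the data shown here, two measured steps bear on this only indirectly. The first is a 3.6-fold higher number from compound 1 to compound 2 (0.55 log units; beyond the scatter) and the second, phenyl in place of methyl on the ring nitrogen, is a 3.0-fold lower number from compound 2 to compound 3 (0.48 log units; beyond the scatter). Both are modest, though beyond the scatter. Among the measured compounds shown here, the second touches the same substituent, but neither tests fluoro, so the data give no direct precedent and no firm direction. Since exchanges of whole groups in compound 2 and compound 3 moved the number only modestly, a single fluoro is expected to leave no step beyond the scatter.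

The expected step is a 1.1-fold lower number from compound 3 to compound 4 (0.02 log units; within the scatter). For compound 4 the estimated value is 18000 nM, with an expected range from 9000 nM to 36000 nM.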

Compound 4, half-maximal inhibitory concentration: 25000 nM
Compound 4: the middle estimate sits 1.4-fold (0.14 log units) below what was measured; low and high end bracket the measured number.
By their numbers in this assay, from the lowest: compounds 1, 3 and 4 (each within the scatter of the next); then compound 2.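

In this assay the first direct test of a substituent on the phenyl of this piperazine series, fluoro in place of hydrogen on an aromatic carbon, ortho to a large group, gives a 1.3-fold higher number from compound 3 to compound 4 (0.12 log units; within the scatter) and so does not separate compound 4 from compound 3. Among these compounds, at this place the fluoro is therefore tolerated without a readable change, which the whole-group exchanges among the earlier compounds could not show. The distance from the methyl compound also survives the fluoro, with a 2.3-fold lower number from compound 2 to compound 4 (0.36 log units; beyond the scatter) as a modest step that stays beyond the scatter, so 2-fluorophenyl on the ring nitrogen holds the separation from methyl seen for phenyl.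

Open, from the compounds shown here alone, is whether a group larger than fluoro on the same aromatic carbon, such as chloro, methoxy or trifluoromethyl, would also stay within the scatter of compound 3, or whether a carboxylic acid there would move the number. Also open, going by these compounds, is whether benzyl or acetyl on the ring nitrogen would land nearer compound 3 or nearer compound 2. No accompanying measurement is available that could account for this result.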